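Swapping a cyanophenyl for a pyridyl on the Bcl-2 series

The compounds below may be only part of what the source reports. "The series", "measured", "known", "first", "only" and "open" are said of these compounds alone.

Measured so far:
- compound 1, `COc1ccccc1C=C1CCN(c2ccc(C(=O)NS(=O)(=O)c3ccc(N[C@H](CCN(C)C)CSc4ccccc4)c([N+](=O)[O-])c3)cc2)CC1`: 250 nM
- compound 2, `CN(C)CC[C@H](CSc1ccccc1)Nc1ccc(S(=O)(=O)NC(=O)c2ccc(N3CCC(=Cc4ccccc4C#N)CC3)cc2)cc1[N+](=O)[O-]`: 1600 nM

Compound 2 stands at the higher of the two numbers measured in a functional assay (FL5.12 cells, Mus musculus) with Apoptosis regulator Bcl-2 (Homo sapiens) as the target; a higher number here means that more compound is needed for the effect, a lower number that less compound is needed; its nearest neighbour is compound 1, and the step of a 6.4-fold higher number from compound 1 to compound 2 (0.81 log units; beyond the scatter) lies beyond the scatter.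

Compound 3, `CN(C)CC[C@H](CSc1ccccc1)Nc1ccc(S(=O)(=O)NC(=O)c2ccc(N3CCC(=Cc4ccccn4)CC3)cc2)cc1[N+](=O)[O-]`, has not been measured. It differs from compound 2 in one place: pyridin-2-yl in place of 2-cyanophenyl on a double-bonded chain carbon bound to a double-bonded ring carbon. For the measured compounds named here, the pyridin-2-yl carries no substituent at all, so the only measured step that speaks to this change is the one from compound 1 to compound 2, which shows that exchanging the group on that aromatic ring moves the number by a modest amount. Going by the values given here, no measured pair shows what removing the substituent and replacing a ring carbon with nitrogen does. The expectation for compound 3 is therefore a loose one: a step of a 2.0-fold lower number from compound 2 to compound 3 (0.30 log units; within the scatter) toward the lower side, with wide uncertainty. Compound 3 is estimated to give 800 nM in this assay, with a likely range from 250 nM to 2500 nM.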

Compound 3, half-maximal effective concentration: 1380 nM
Beside the measured number, compound 3's estimate is 1.7-fold (0.24 log units) below it; low and high end bracket the measured number.
By their numbers in this assay, from the lowest: compound 1; then compounds 3 and 2 (each within the scatter of the next).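

In this assay, putting pyridin-2-yl in place of 2-cyanophenyl on a double-bonded chain carbon bound to a double-bonded ring carbon gives a 1.2-fold lower number from compound 2 to compound 3 (0.06 log units; within the scatter) and so leaves the two groups indistinguishable here, even though the pyridin-2-yl has no triple bond and carries its nitrogen in the ring. The higher number of compound 2 is therefore not tied to the nitrile, since compound 3 has no nitrile yet stays within the scatter of compound 2. The 2-methoxyphenyl group of compound 1 remains apart from the pyridin-2-yl as well, with a 5.5-fold higher number from compound 1 to compound 3 (0.74 log units; beyond the scatter) as a modest step, and among these three compounds it alone stands apart at this position.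

Whether the methoxy group itself accounts for the lower number of compound 1 stays open, as does the role of the ring nitrogen: an unsubstituted phenyl at this place, or a methoxy group on the pyridin-2-yl, would pull those two changes apart. Nothing available here explains why the numbers fall this way.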